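The compounds below may be only part of what the source reports. "The series", "measured", "known", "first", "only" and "open" are said of these compounds alone.

Among the measured compounds shown here, in a functional assay on OVCAR-8 cells (Homo sapiens) for antiproliferative activity (on this read-out lower numbers stand for stronger inhibition and higher numbers for weaker inhibition), compound 1 `C=CC[C@@H]1C[C@@H](c2ccc(Cl)c(Cl)c2)[C@H](NC(=O)c2cc(-c3c(Cl)cnn3C)c(Cl)o2)CN1` gives 990 nM and compound 2 `Cn1ncc(Cl)c1-c1cc(C(=O)N[C@@H]2CN[C@H](CCO)C[C@H]2c2ccc(Cl)c(Cl)c2)oc1Cl` gives 610 nM, so compound 2 cannot be separated from the only other measured compound. Compound 3 `Cn1ncc(Cl)c1-c1cc(C(=O)N[C@@H]2CN[C@H](CC(=O)NC3CCC3)C[C@H]2c2ccc(Cl)c(Cl)c2)oc1Cl` differs from compound 2 on a saturated chain carbon bound to a saturated ring carbon: cyclobutylcarbamoyl in place of hydroxymethyl on a saturated chain carbon bound to a saturated ring carbon. For the measured compounds named here, the only measured step at this place, a 1.6-fold lower number from compound 1 to compound 2 (0.21 log units; within the scatter), lies within the scatter, and no compound with cyclobutylcarbamoyl has a measured value yet. No step beyond the scatter is therefore expected. The expected step is a 1.2-fold lower number from compound 2 to compound 3 (0.09 log units; within the scatter). For compound 3 the estimate is 500 nM, with an expected range of 150 nM to 1600 nM.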

Compound 3, half-maximal inhibitory concentration: 610 nM
For compound 3 the middle estimate is 1.2-fold (0.09 log units) below the measured one; the range from low to high includes it.
By their numbers in this assay, from the lowest: compounds 2, 3 and 1 (each within the scatter of the next).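

In this assay, cyclobutylcarbamoyl, with 7 heavy atoms and a four-membered ring, replaces the 2 heavy atoms of hydroxymethyl on a saturated chain carbon bound to a saturated ring carbon, and the result is no change at the digits printed from compound 2 to compound 3 (within the scatter). Measured against vinyl, the same group gives a 1.6-fold lower number from compound 1 to compound 3 (0.21 log units; within the scatter), so the three groups seen at this place cannot be told apart, even with a much bulkier group added. No other evidence bears on this result. From the compounds shown here alone, whether an amine, a carboxylic acid or a longer chain at this place would give a step beyond the scatter remains open.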